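Methyl for Chloro on Two Benzyl-Bearing Inhibitor Cores

A few compounds are considered here, and "the series" means these few. Any claim that something is new, unique, unknown or untested is made for them only; others in the source may bear on it.

Of the compounds shown here, three have so far been tested in an assay on isolated protein (adrenal medulla) for inhibition of Dopamine beta-hydroxylase (Bos taurus); on this read-out higher numbers stand for weaker inhibition and lower numbers for stronger inhibition. Compound 1 `Nc1ncn(Cc2ccccc2Cl)c2ncnc1-2` gives 200 ug/mL, compound 2 `Nc1ncn(Cc2ccc(Cl)cc2)c2ncnc1-2` gives 20 ug/mL, and compound 3 `Cc1ccccc1Cn1cnc(N)c2ncnc1-2` gives 200 ug/mL. Compound 2 is the strongest inhibitor of the three, since its steps to both of the others lie beyond the scatter. The difference between the core of compound 1 and the core of compound 2 is not broken down here. Compound 3 differs from compound 1 by a single change, (methyl in place of chloro on an aromatic carbon), and that step, no change at the digits printed from compound 1 to compound 3 (within the scatter), left the inhibition where it was.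

Compound 4 `Cc1ccc(Cn2cnc(N)c3ncnc2-3)cc1` has not yet been measured. It differs from compound 2 by methyl in place of chloro on an aromatic carbon, the same kind of change as that from compound 1 to compound 3, but made where the group sits para to a large group rather than ortho to it. Going by the values given here, with only that one earlier example to go on, the step from compound 2 to compound 4 is expected to be no change at the digits printed from compound 2 to compound 4 (within the scatter), matching the earlier unchanged result because of no change at the digits printed from compound 1 to compound 3 (within the scatter). Compound 4 is therefore estimated at 20 ug/mL, with a likely range from 8 ug/mL to 60 ug/mL.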

Compound 4, half-maximal inhibitory concentration: 20 ug/mL
The estimate for compound 4 equals the measured number at the digits printed, and the stated range covers the measured number.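

In this assay, methyl in place of chloro on an aromatic carbon gave no change at the digits printed from compound 2 to compound 4 (within the scatter), and this step can be set directly beside the same change on the other core: the same change on two cores in this assay, no change at the digits printed (within the scatter) from compound 1 to compound 3 and no change at the digits printed (within the scatter) from compound 2 to compound 4, 1.0-fold (0.00 log units) apart, within the scatter of two such steps. On these two cores, then, the swap carried over with the same result, both where the inhibition is weaker and where it is stronger, and in compound 4 the group sits para to a large group. This shows agreement across just two pairs of compounds, so it sets no general rule for other cores and says nothing about why the two groups give matching numbers.

Still open, from the compounds shown here alone, is how other groups at the same place would compare with chloro and methyl, for example fluoro, methoxy, an amine or a carboxylic acid. Also open, going by these compounds, is whether methyl and chloro would match on a third core or at other places on the benzyl ring.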